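The source may report more compounds than this note shows. Statements on the series, on what has been measured and on what is new or still open speak of the compounds shown alone.

Compound 1: `CC(C)C(c1nnc[nH]1)c1ccc(-c2ccc3cccc(F)c3c2)[nH]c1=O`, 21 nM in a functional assay on CHO cells for antagonist activity at prostaglandin E2 receptor EP3 subtype (Homo sapiens), read by cAMP accumulation; a lower number here means a stronger inhibitor, a higher number a weaker inhibitor
Compound 2: `CC(C)C(Cc1nnn[nH]1)c1ccc(-c2ccc3cccc(F)c3c2)[nH]c1=O`, 134 nM in this assay

Compound 2 stands at the higher of these two numbers; its nearest neighbour, compound 1, lies a clearly lower step away, as a 6.4-fold higher number from compound 1 to compound 2 (0.80 log units; beyond the scatter) shows. Compound 3 is `CC(C)C(c1noc(=O)[nH]1)c1ccc(-c2ccc3cccc(F)c3c2)[nH]c1=O`, not yet measured. Relative to compound 2 the change is a group of 6 heavy atoms (2 carbon, 2 nitrogen, 2 oxygen; one five-membered aromatic ring with 3 hetero atoms) in place of a group of 6 heavy atoms (2 carbon, 4 nitrogen; one five-membered aromatic ring with 4 hetero atoms), on a saturated chain carbon bound to an aromatic carbon and a saturated chain carbon. Among the measured compounds shown here, the only measured step that bears on it is a 6.4-fold higher number from compound 1 to compound 2 (0.80 log units; beyond the scatter), where a directly attached five-membered ring gave way to a ring held on a one-carbon chain and the number rose beyond the scatter. Compound 3 returns to a directly attached ring, though a different one, so a modest step downward in this assay is expected rather than none. For compound 3 the estimate is 45 nM, with a range from 12 nM to 160 nM, meaning an expected step of a 3.0-fold lower number from compound 2 to compound 3 (0.47 log units; beyond the scatter).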

Compound 3, half-maximal inhibitory concentration: 41 nM
Compound 3: the middle estimate sits 1.1-fold (0.04 log units) above what was measured; measured number inside the range.
By their numbers in this assay, from the lowest: compounds 1 and 3 (each within the scatter of the next); then compound 2.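

In this assay, a five-membered aromatic ring with 3 hetero atoms, 2 oxygen atoms in its group and a double bond outside the ring, stands in place of the (1H-tetrazol-5-yl)methyl group, giving a 3.3-fold lower number from compound 2 to compound 3 (0.51 log units; beyond the scatter). Set against the 4H-1,2,4-triazol-3-yl group at the same place, this different ring gives a 2.0-fold higher number from compound 1 to compound 3 (0.29 log units; within the scatter), so the two cannot be told apart here. Among the compounds shown here, on this saturated chain carbon, then, two different directly attached rings now share the lower numbers, while compound 2, the only one with its ring held on a one-carbon chain, keeps the highest.

Nothing shown gives a reason for these numbers, and the step from compound 2 changes both the ring and the chain. Still open, on these data alone, is how a carboxylic acid at this carbon, or the 4H-1,2,4-triazol-3-yl ring on a one-carbon chain, would compare.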